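The source may report more compounds than this note shows. Statements on the series, on what has been measured and on what is new or still open speak of the compounds shown alone.

Measured so far in a functional assay on NCI-H226 cells (Homo sapiens) for cytotoxicity, read by sulforhodamine B assay, with a stated time of 24 h; on this read-out higher numbers stand for weaker inhibition of growth and lower numbers for stronger inhibition of growth:
Compound 1, `COc1ccc(C(=O)/C=C/c2cc3ccccc3[nH]c2=O)cc1`: 5570 nM
Compound 2, `O=C(/C=C/c1cc2ccccc2[nH]c1=O)c1ccc(O)cc1`: 3290 nM

Among the compounds with values here, compound 2 stands lowest of these two numbers, though the only measured step, a 1.7-fold lower number from compound 1 to compound 2 (0.23 log units; within the scatter), lies within the scatter; that step is hydrogen in place of methyl on an oxygen on an aromatic ring.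

Compound 3, `O=C(/C=C/c1cc2ccccc2[nH]c1=O)c1ccc(Cl)cc1`, differs from compound 2 by chloro in place of hydroxy on an aromatic carbon; cut one bond further out, the difference reads 4-hydroxyphenyl to 4-chlorophenyl. Within the data shown here, no measured step bears directly on this exchange: the single step recorded, methoxy to hydroxy, is a different change at the same place, and it stayed within the scatter. With both measured compounds sitting close together, nothing in the data points to a shift beyond the scatter in this assay in either direction. Compound 3 is therefore expected to give about 2800 nM, between 1000 nM and 9000 nM, which means an expected step of a 1.2-fold lower number from compound 2 to compound 3 (0.07 log units; within the scatter).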

Compound 3, concentration for 50% growth inhibition: 11600 nM
The estimate for compound 3 lay 4.1-fold (0.62 log units) below the measured number; measured number outside the range, above it.
By their numbers in this assay, from the lowest: compounds 2 and 1 (each within the scatter of the next); then compound 3.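

In this assay the place on the aromatic ring para to a large group turns out to respond to the group it carries: chloro in place of hydroxy gives a 3.5-fold higher number from compound 2 to compound 3 (0.55 log units; beyond the scatter) and chloro in place of methoxy gives a 2.1-fold higher number from compound 1 to compound 3 (0.32 log units; beyond the scatter) on the same ring carbon. Both steps are modest but lie beyond the scatter, whereas compound 1 and compound 2 stayed within the scatter of each other, so among these three compounds only chloro separates from the rest, towards weaker inhibition of growth. Nothing measured here bears on why this exchange moves the number.

The compounds shown leave open whether an amine, a fluoro group or a carboxylic acid at this place would side with chloro or with hydroxy and methoxy. They also leave open whether chloro on another carbon of the ring would give a step of similar size.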